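A few compounds are considered here, and "the series" means these few. Any claim that something is new, unique, unknown or untested is made for them only; others in the source may bear on it.

Measured so far:
compound 1 `Cn1c(Cc2nn(C)c(=O)c3ccccc23)nnc1SCCCCCCCC(=O)Nc1ccc(F)cc1F` — 2300 nM
compound 2 `Cn1c(Cc2nn(C)c(=O)c3ccccc23)nnc1SCCCCCCCCCCC(=O)Nc1ccccc1Cl` — 15000 nM

Both compounds were tested in an assay on isolated protein (Mus musculus) for inhibition of IL15-IL15 receptor (Homo sapiens), read by resazurin assay, with stated times of 30 min and 2.5 days; on this read-out lower numbers stand for stronger inhibition and higher numbers for weaker inhibition. Compound 1 gives 2300 nM, the lower of the two numbers. Compound 2 gives 15000 nM, and the gap between the two lies beyond the usual scatter of repeated measurements. Compound 2 differs from compound 1 in more than one place, so these two values alone do not show what any single change contributes.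

The compound not yet measured is compound 3 `Cn1c(Cc2nn(C)c(=O)c3ccccc23)nnc1SCCCCCCCC(=O)Nc1ccc(Cl)cc1`. It differs from compound 1 in one place: 4-chlorophenyl in place of 2,4-difluorophenyl on an amide-type nitrogen. For the measured compounds named here, no pair of measured compounds isolates this change, so there is no measured step to lean on. With the chain and the shared core left unchanged and only the aryl group on the amide nitrogen replaced, the expectation is a step of modest size, within the scatter, from compound 1 to compound 3, namely a 1.3-fold higher number from compound 1 to compound 3 (0.12 log units; within the scatter). Compound 3 is therefore expected to give about 3000 nM, with a likely range from 1000 nM to 9000 nM.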

Compound 3, half-maximal inhibitory concentration: 800 nM
The estimate for compound 3 lay 3.8-fold (0.57 log units) above the measured number, and the stated range ends above it.
By their numbers in this assay, from the lowest: compound 3; then compound 1; then compound 2.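

In this assay, the aryl group on the amide-type nitrogen turns out to matter: putting 4-chlorophenyl in place of 2,4-difluorophenyl, with the chain and the shared core untouched, gives a 2.9-fold lower number from compound 1 to compound 3 (0.46 log units; beyond the scatter). For the compounds shown here, compound 1 and compound 2 differ in more than one place, so this is the first comparison here in which a single change can be read, and it shows that this position alone can move the number by more than the usual scatter of repeated measurements. Nothing available here explains why this replacement lowers the number.

As far as these compounds go, this one step makes several changes at once, since the fluorines of 2,4-difluorophenyl leave while the chlorine of 4-chlorophenyl enters, so it remains open whether the lower number goes with gaining the chlorine or losing the fluorines, a question that an unsubstituted phenyl or a 4-fluorophenyl on the same chain could help answer. From the compounds shown here alone, it also remains open whether 4-chlorophenyl would give a similar step on a longer chain, or how other groups at this position, such as 4-bromophenyl or 4-methoxyphenyl, would compare.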